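The source may hold more compounds than are shown below. What is called first, only, known or untested is meant among the compounds shown, and "the series" means these compounds.

Three compounds with the same fused core have been examined in a functional assay on NCI-H23 cells (Homo sapiens) for cytotoxicity, read by sulforhodamine B assay, with a stated time of 48 h; a higher number here means that more compound is tolerated, a lower number that less compound is tolerated. Compound 1 `ClCc1cccc(Cn2cnc3ncnc(Cl)c32)c1` gives 5880 nM in this assay. Compound 2 `ClCc1ccccc1Cn1cnc2ncnc(Cl)c21` gives 49000 nM, and compound 3 `ClCc1ccc(Cn2cnc3c(Cl)nc(Cl)nc32)cc1` gives 58900 nM. Compound 1 thus stands at the lowest of the three numbers; compound 2 lies nearest to it and compound 3 furthest, and both of those gaps are beyond the usual scatter of this measurement.

Compound 4 `ClCc1cccc(Cn2cnc3nc(Cl)nc(Cl)c32)c1` has not yet been measured. It differs from compound 1 in one place: chloro in place of hydrogen on an aromatic carbon. Among the compounds with values here, no measured pair shows exactly this change on its own, so the step from compound 1 to compound 4 cannot be read off from the data; compound 3 also carries two chloro groups but differs from compound 1 in a second place as well, so its value only shows that a dichloro compound in this set sits high.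

On this basis a step upward, beyond the scatter, is expected, as a 2.6-fold higher number from compound 1 to compound 4 (0.41 log units; beyond the scatter) expresses. Compound 4 is therefore estimated at 15000 nM, within a range from 4000 nM to 60000 nM.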

Compound 4, concentration lethal to 50% of the cells: 5370 nM
Estimate against measurement, compound 4: 2.8-fold (0.45 log units) above, and the stated range covers the measured number.
By their numbers in this assay, from the lowest: compounds 4 and 1 (each within the scatter of the next); then compounds 2 and 3 (each within the scatter of the next).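

In this assay, within the data shown here, chloro in place of hydrogen on an aromatic carbon, between two ring nitrogen atoms, comes out as a 1.1-fold lower number from compound 1 to compound 4 (0.04 log units; within the scatter), the first direct reading of this change at this position, and it lies within the scatter. The position therefore carries a chloro group with no change that this measurement can separate, and compound 4 shows that two chloro groups on the shared core do not by themselves bring a high number. Nothing at hand gives a reason for this result.

From the compounds shown here alone, whether the position would behave the same with an amine, a methoxy group or a longer chain in place of the chloro group remains open. Going by these compounds, it is also open whether the same change would read alike on the side chain arrangement of compound 2.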